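Fluoro to methyl on the shared core

The compounds below may be only part of what the source reports. "The series", "measured", "known", "first", "only" and "open" are said of these compounds alone.

In a functional assay on A549 cells (Homo sapiens) for inhibition, read by MTT assay, with a stated time of 72 h (a higher number here means a weaker inhibitor, a lower number a stronger inhibitor), the measured values are:
compound 1 `COc1ccc(-c2cc(=O)oc3ccc(Cl)cc23)cc1O` gives 400 nM
compound 2 `COc1ccc(-c2cc(=O)oc3ccc(F)cc23)cc1O` gives 1500 nM

Of these two, compound 2 has the higher number and so is the weaker inhibitor. Compound 3 `COc1ccc(-c2cc(=O)oc3ccc(C)cc23)cc1O` carries methyl in place of fluoro on an aromatic carbon in this change. Going by the values given here, one measured step bears on it, at the same carbon: a 3.8-fold higher number from compound 1 to compound 2 (0.57 log units; beyond the scatter) for fluoro in place of chloro, a modest step beyond the scatter. Among the compounds with values here, no methyl compound has been measured, so the direction is uncertain, but a modest step to a lower number in this assay is expected. The expected change is a 2.1-fold lower number from compound 2 to compound 3 (0.33 log units; beyond the scatter) in this estimate. Compound 3 is estimated at 700 nM with a range from 250 nM to 2000 nM in this estimate.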

Compound 3, half-maximal inhibitory concentration: 200 nM
For compound 3 the middle estimate is 3.5-fold (0.54 log units) above the measured one, outside the stated range (below it).
By their numbers in this assay, from the lowest: compounds 3 and 1 (each within the scatter of the next); then compound 2.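

In this assay methyl in place of fluoro gives the largest step yet seen at this carbon, a 7.5-fold lower number from compound 2 to compound 3 (0.88 log units; beyond the scatter). Methyl in place of chloro gives a 2.0-fold lower number from compound 1 to compound 3 (0.30 log units; within the scatter), which lies within the scatter, so these two groups cannot be ranked here, while compound 2 stands apart as the weakest of the three. No measurement shown here explains these differences. Still open, going by these compounds, is whether a longer chain such as ethyl would keep this level. An amine or a methoxy group at the same carbon is equally untested by these compounds.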